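The source may report more compounds than this note shows. Statements on the series, on what has been measured and on what is new or still open speak of the compounds shown alone.

Measured so far in a functional assay on PC-3 cells (Homo sapiens) for inhibition, read by sulforhodamine B assay, with a stated time of 48 h; a lower number here means a stronger inhibitor, a higher number a weaker inhibitor:
Compound 1 `COc1cc(Cl)cc(-c2nn(-c3cccc(NC(=O)Nc4cccc(C(F)(F)F)c4)c3)cc2-c2ccncc2)c1` gives 420 nM.
Compound 2 `COc1cc(Cl)cc(-c2nn(-c3cccc(NC(=O)c4cccc(C(F)(F)F)c4)c3)cc2-c2ccncc2)c1` gives 2710 nM.
Compound 3 `O=C(Nc1cccc(-n2cc(-c3ccncc3)c(-c3cc(O)cc(Cl)c3)n2)c1)Nc1ccc(Cl)c(Cl)c1` gives 1690 nM.

Compound 1 holds the lowest number of the three in this assay; compound 3 stands nearest and compound 2 furthest, both gaps beyond the scatter. Within the data shown here, the one measured single-change step is a 6.5-fold higher number from compound 1 to compound 2 (0.81 log units; beyond the scatter), which concerns the carbonyl side of the urea and carries no information on the aryl at the urea nitrogen. Compound 4 `COc1cc(Cl)cc(-c2nn(-c3cccc(NC(=O)Nc4ccc(Cl)c(Cl)c4)c3)cc2-c2ccncc2)c1` is compound 1 with 3,4-dichlorophenyl in place of 3-(trifluoromethyl)phenyl on an amide-type nitrogen. Among the measured compounds shown here, no measured step isolates this exchange. Compound 3 carries the same 3,4-dichlorophenyl urea and shows a higher number than compound 1, but compound 3 also differs from compound 1 elsewhere on the shared core, so only part of that gap can be ascribed to the aryl. Compound 4 is therefore expected to give a modestly higher number, an estimated step of a 2.0-fold higher number from compound 1 to compound 4 (0.31 log units; beyond the scatter). Compound 4 is estimated at 850 nM, with a range from 300 nM to 2500 nM.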

Compound 4, half-maximal inhibitory concentration: 1130 nM
The estimate for compound 4 lay 1.3-fold (0.12 log units) below the measured number, within the range that was stated.
By their numbers in this assay, from the lowest: compound 1; then compounds 4, 3 and 2 (each within the scatter of the next, the first and the last beyond it).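

In this assay, the aryl on the urea nitrogen is now isolated as a single change, and 3,4-dichlorophenyl in place of 3-(trifluoromethyl)phenyl gives a 2.7-fold higher number from compound 1 to compound 4 (0.43 log units; beyond the scatter). With 3,4-dichlorophenyl held, methyl in place of hydrogen on the aromatic oxygen gives a 1.5-fold lower number from compound 3 to compound 4 (0.17 log units; within the scatter), so this pair does not separate and the oxygen substituent shows no measurable effect here. The dichlorophenyl urea also stands apart from the trifluoromethylphenyl amide, with a 2.4-fold lower number from compound 2 to compound 4 (0.38 log units; beyond the scatter), although that step changes both the carbonyl side and the aryl.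

No independent data bear on why these steps occur. From the compounds shown here alone, it remains open how this position would respond to an amine or a carboxylic acid on the phenyl ring, or to a single chlorine in place of the two.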